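The source may hold more compounds than are shown below. What is called first, only, known or untested is meant among the compounds shown, and "the series" means these compounds.

Of the compounds shown here, two sharing one core have been tested in an assay on HEK293 cells for displacement of a labelled ligand from Urotensin-2 receptor (Homo sapiens), read by fluorescence, with a stated time of 90 min; a higher number here means a weaker inhibitor, a lower number a stronger inhibitor. Compound 1, `O=C(NC1CCN(Cc2ccc(OC3CCNCC3)c(Br)c2)CC1)c1ccccn1`, gives 120 nM in this assay. Compound 2, `O=C(NC1CCN(Cc2ccc(OC3CCNCC3)c(Br)c2)CC1)c1cc2cc(C(F)(F)F)ccc2s1`, gives 100 nM in this assay. Compound 2 carries the lower of the two numbers, yet its gap to compound 1 lies within the scatter of repeated measurements, so on these data the two cannot be told apart. Compound 3, `CCc1ccc2sc(C(=O)NC3CCN(Cc4ccc(OC5CCNCC5)c(Br)c4)CC3)cc2c1`, has not yet been measured. It differs from compound 2 in a single place: ethyl in place of trifluoromethyl on an aromatic carbon. Among the measured compounds shown here, no pair of measured compounds shows a step of this kind, so nothing here tells how large the change should be. A modest step in either direction, or none beyond the scatter, is expected. Compound 3 is estimated at 120 nM in this assay, with a range from 40 nM to 400 nM. That amounts to an expected step of a 1.2-fold higher number from compound 2 to compound 3 (0.08 log units; within the scatter).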

Compound 3, half-maximal inhibitory concentration: 180 nM
Beside the measured number, compound 3's estimate is 1.5-fold (0.18 log units) below it; the range from low to high includes it.
By their numbers in this assay, from the lowest: compounds 2, 1 and 3 (each within the scatter of the next).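

In this assay, putting ethyl in place of trifluoromethyl on the six-membered aromatic ring gives a 1.8-fold higher number from compound 2 to compound 3 (0.26 log units; within the scatter), so this first change at the position leaves the two compounds indistinguishable. Exchanging the whole group on the carbonyl carbon, 5-ethyl-1-benzothiophen-2-yl in place of pyridin-2-yl, gives a 1.5-fold higher number from compound 1 to compound 3 (0.18 log units; within the scatter), so all three compounds remain within the scatter of their neighbours and neither change has yet produced a clear difference. Nothing available here accounts for this result.

From the compounds shown here alone, it remains open whether an amine, a carboxylic acid or a longer chain such as butyl at this aromatic carbon would produce a step beyond the scatter. The same question applies to plain hydrogen, which would show whether any group at this position matters at all.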